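A few compounds are considered here, and "the series" means these few. Any claim that something is new, unique, unknown or untested is made for them only; others in the source may bear on it.

Compound 1, `Cc1ccc(/C=C/C(=O)Nc2ccc3nc(N4CCC(O)(C5CC5)CC4)nc(C)c3c2)cc1`, gives 107 nM in a functional assay on CHO-K1 cells for antagonist activity at melanin-concentrating hormone receptor 1 (Homo sapiens), read by inositol phosphate accumulation, with stated times of 10 min and 45 min; on this read-out lower numbers stand for stronger inhibition and higher numbers for weaker inhibition. Among the three measured compounds it stands second highest. Among the measured compounds shown here, compound 2, `Cc1nc(NCCNS(C)(=O)=O)nc2ccc(NC(=O)/C=C/c3ccc(OC(F)(F)F)cc3)cc12`, gives 142 nM in this assay, a number that lies within the usual scatter of the one for compound 1, so the two cannot be ranked. Compound 3, `Cc1nc(N2CCC(NS(=O)(=O)N(C)C)CC2)nc2ccc(NC(=O)/C=C/c3ccc(OC(F)(F)F)cc3)cc12`, gives 31 nM in this assay, a number beyond the scatter from compound 1 and the lowest of the three.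

Compound 4, `Cc1nc(N2CCC(O)(C3CC3)CC2)nc2ccc(NC(=O)/C=C/c3ccc(C(F)(F)F)cc3)cc12`, differs from compound 1 in one place: trifluoromethyl in place of methyl on an aromatic carbon. For the measured compounds named here, no measured pair shows this change on its own. The two compounds that carry a trifluoromethoxy group at the corresponding place, compound 2 and compound 3, give numbers on either side of compound 1, so the record offers no clear direction for a fluorinated group there. The step of a 1.5-fold lower number from compound 1 to compound 4 (0.18 log units; within the scatter) is therefore expected to be modest, toward a lower number but not far beyond the scatter. Compound 4 is expected to give about 70 nM in this assay, with a range from 25 nM to 200 nM.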

Compound 4, half-maximal inhibitory concentration: 83 nM
Compound 4: middle estimate off by 1.2-fold (0.07 log units), on the low side; measured number inside the range.
By their numbers in this assay, from the lowest: compound 3; then compounds 4, 1 and 2 (each within the scatter of the next).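

Among the compounds shown here, compound 4 gives the first direct reading of this change: going from 4-methylphenyl to 4-(trifluoromethyl)phenyl, with the rest of the molecule unchanged, yields a 1.3-fold lower number from compound 1 to compound 4 (0.11 log units; within the scatter) in this assay, so the two compounds cannot be ranked. At this place on the aromatic ring, para to a large group, trifluoromethyl thus stands in for methyl with no difference that the read-out can separate from scatter. Nothing measured here offers an explanation for this result.

The compounds shown leave open how other groups would read at this place, such as a chlorine atom, a nitrile or a methoxy group. They also leave open whether trifluoromethyl and methyl would stay indistinguishable when paired with the sulfonamide-bearing groups of compound 2 and compound 3.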